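The compounds below may be only part of what the source reports. "The series", "measured", "known", "first", "only" and "open" are said of these compounds alone.

Of the compounds shown here, three built on one shared core have so far been measured in an assay on CHO cells for agonist activity at 5-hydroxytryptamine receptor 1D (Homo sapiens), read by GTPgammaS binding; on this read-out lower numbers stand for an effect already at smaller amounts and higher numbers for an effect only at larger amounts of compound. Compound 1 `CC(=O)Nc1ccc(CNC2CCN(CCCc3c[nH]c4ccc(-n5cnnc5)cc34)CC2)cc1` gives 5 nM in this assay. Compound 2 `NC(=O)OC[C@H](NC1CCN(CCCc2c[nH]c3ccc(-n4cnnc4)cc23)CC1)c1ccccc1` gives 9.3 nM, and compound 3 `C[C@H](NC1CCN(CCCc2c[nH]c3ccc(-n4cnnc4)cc23)CC1)c1ccccc1` gives 12 nM. Compound 3 thus holds the highest number of the three; its nearest neighbour is compound 2, and the two lie within the scatter of each other, while the gap to compound 1 is modest and beyond the scatter, as a 2.4-fold higher number from compound 1 to compound 3 (0.38 log units; beyond the scatter) shows. The remaining steps are a 1.9-fold higher number from compound 1 to compound 2 (0.27 log units; within the scatter) and a 1.3-fold higher number from compound 2 to compound 3 (0.11 log units; within the scatter).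

Compound 4 `CC(CO)(NC1CCN(CCCc2c[nH]c3ccc(-n4cnnc4)cc23)CC1)c1ccccc1` has not yet been measured. It differs from compound 3 in one place: 1-(hydroxymethyl)-1-phenylethyl in place of 1-phenylethyl on an amine nitrogen. The measured step that bears most on this change is a 1.3-fold higher number from compound 2 to compound 3 (0.11 log units; within the scatter), which ran within the scatter when a carbamoyloxy group left the chain carbon; the entering 1-(hydroxymethyl)-1-phenylethyl group brings back one hydrogen-bond donor and one hydrogen-bond acceptor on that chain, together with a further methyl on the same carbon. Among the compounds with values here, no measured pair shows a methyl added at this carbon, so that part of the change is untested. Compound 4 is therefore expected to stay close to compound 3. The step expected is a 1.3-fold higher number from compound 3 to compound 4 (0.10 log units; within the scatter), within the scatter. The estimate for compound 4 is 15 nM, with a range from 6 nM to 40 nM.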

Compound 4, half-maximal effective concentration: 3.4 nM
Beside the measured number, compound 4's estimate is 4.4-fold (0.64 log units) above it; measured number below the stated range.
By their numbers in this assay, from the lowest: compounds 4, 1, 2 and 3 (each within the scatter of the next, the first and the last beyond it).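

In this assay, the entering 1-(hydroxymethyl)-1-phenylethyl group on the amine nitrogen gives a 3.5-fold lower number from compound 3 to compound 4 (0.55 log units; beyond the scatter) and so moves the number beyond the scatter, whereas the earlier change on this chain, with a 1.3-fold higher number from compound 2 to compound 3 (0.11 log units; within the scatter), stayed within it. The number at this position therefore does respond to a change on this chain carbon: the same group gives a 2.7-fold lower number from compound 2 to compound 4 (0.44 log units; beyond the scatter) against the 2-(carbamoyloxy)-1-phenylethyl group, while a 1.5-fold lower number from compound 1 to compound 4 (0.17 log units; within the scatter) places it within the scatter of the 4-acetamidobenzyl group, so three quite different groups on this nitrogen do not all give the same result. No evidence is at hand that would explain this step.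

The change joins a further methyl and a hydroxymethyl on one carbon, and the compounds shown do not separate the two, so it remains open what a 2-hydroxy-1-phenylethyl or a 1-methyl-1-phenylethyl group would give at this place. Also open, as far as these compounds go, are an aminomethyl or a methoxymethyl group in place of the hydroxymethyl, and how the two mirror-image forms of compound 4 compare, as its entering group has no defined stereocentre.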